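The source may hold more compounds than are shown below. What is called first, only, known or untested is meant among the compounds shown, and "the series" means these compounds.

Compound 1, `CC(C)C[C@H](N)c1cc(C(F)(F)F)ccc1N1CCN(C(=O)[C@H](C)Cc2ccc(Cl)cc2)CC1`, gives 31 nM in an assay on HEK293 cells for displacement of a labelled ligand from Melanocortin receptor 4 (Homo sapiens); on this read-out lower numbers stand for stronger inhibition and higher numbers for weaker inhibition.
Compound 2, `CC(C)C[C@H](N)c1cc(C(F)(F)F)ccc1N1CCN(C(=O)CCNC2CCCCC2)CC1`, gives 4800 nM in this assay.

Of the two compounds measured, compound 2 stands at the highest number, which on this read-out is the weaker end. Among the compounds with values here, the one measured step that reaches it is a 150-fold higher number from compound 1 to compound 2 (2.19 log units; beyond the scatter), a large loss that came with the exchange of the 1-(4-chlorobenzyl)ethyl group for the 2-(cyclohexylamino)ethyl chain on the carbonyl carbon.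

Compound 3, `CC(C)C[C@H](N)c1cc(C(F)(F)F)ccc1N1CCN(C(=O)COc2ccc(Cl)cc2)CC1`, has not been measured. It differs from compound 2 in one place: 4-chlorophenoxy in place of (cyclohexylamino)methyl on a saturated chain carbon bound to a carbonyl carbon. This change undoes much of what the measured step introduced: the cyclohexylamino chain leaves, and a chlorinated aromatic ring returns, now as 4-chlorophenoxy instead of the 1-(4-chlorobenzyl)ethyl of compound 1. Within the data shown here, only one step bears on this, a 150-fold higher number from compound 1 to compound 2 (2.19 log units; beyond the scatter), and it was large. A large step in the opposite direction, to a lower number in this assay, is therefore expected for compound 3, though the new ring is not the same group as in compound 1, so the full return is uncertain. For compound 3 the expected value in this assay is 70 nM, with a range of 15 nM to 400 nM. This estimate means a step of a 69-fold lower number from compound 2 to compound 3 (1.84 log units; beyond the scatter).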

Compound 3, inhibition constant: 2900 nM
Beside the measured number, compound 3's estimate is 41-fold (1.62 log units) below it; the whole stated range lies below it.
By their numbers in this assay, from the lowest: compound 1; then compounds 3 and 2 (each within the scatter of the next).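

In this assay, the exchange at this position, on a saturated chain carbon bound to a carbonyl carbon, gives a 1.7-fold lower number from compound 2 to compound 3 (0.22 log units; within the scatter), so 4-chlorophenoxy and (cyclohexylamino)methyl cannot be told apart here, even though one brings an aromatic ring with chlorine and the other a non-aromatic ring with an amine nitrogen. The other new comparison gives a 94-fold higher number from compound 1 to compound 3 (1.97 log units; beyond the scatter), which shows that a chlorinated aromatic ring on this side of the carbonyl is not enough by itself: how that ring is attached matters, and compound 1 remains the strongest of the three. Nothing in the available evidence accounts for either result.

The group of compound 1 and (4-chlorophenoxy)methyl differ in more than one feature, including the ether oxygen, the length of the chain and the branching methyl, so these compounds cannot show which feature carries the large step. On these data alone, a 2-(4-chlorophenyl)ethyl group, with an all-carbon chain but no branching methyl, would help separate these features, and the opposite configuration at the branched carbon of compound 1 also remains open.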